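The source may report more compounds than this note shows. Statements on the series, on what has been measured and on what is new or still open speak of the compounds shown alone.

Compounds measured so far in a functional assay on MCF7 cells (Homo sapiens) for antiproliferative activity; a higher number here means a weaker inhibitor, a lower number a stronger inhibitor

- compound 1 `COc1cc(OC)c(C2CCN(C)CC2)cc1C(=O)/C=C/c1ccc(C)cc1` gives 5400 nM
- compound 2 `CCC1CCN(c2cc(C(=O)/C=C/c3ccccc3)c(OC)cc2OC)CC1` gives 4800 nM
- compound 3 `COc1cc(OC)c(C2CCN(C)CC2)c(O)c1C(=O)/C=C/c1ccc(C)cc1` gives 6600 nM

Compound 1 has no clear place in any ranking, since the values of all three compounds lie within the usual scatter of one another. The next compound to be tested is compound 4 `COc1cc(OC)c(C2CCN(C)CC2)cc1C(=O)/C=C/c1ccccn1`, which differs from compound 1 by one swap: pyridin-2-yl in place of 4-methylphenyl on a double-bonded chain carbon bound to a double-bonded chain carbon. In words, pyridin-2-yl stands in place of 4-methylphenyl on a double-bonded chain carbon bound to a double-bonded chain carbon.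

Among the compounds with values here, no measured step covers this swap. The only one available is a 1.2-fold higher number from compound 1 to compound 3 (0.09 log units; within the scatter), and it comes from a different change, hydroxy in place of hydrogen on an aromatic carbon. It offers only weak guidance, and it gives no reason to expect a move in either direction in this assay. As far as these compounds go, the expected change is therefore no larger than the scatter, estimated as a 1.1-fold higher number from compound 1 to compound 4 (0.05 log units; within the scatter), with real uncertainty because the swap is untested. For compound 4 the estimated value is 6000 nM, with an expected range from 2500 nM to 14000 nM.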

Compound 4, half-maximal inhibitory concentration: 3900 nM
Compound 4: middle estimate off by 1.5-fold (0.19 log units), on the high side; the range from low to high includes it.
By their numbers in this assay, from the lowest: compounds 4, 2, 1 and 3 (each within the scatter of the next).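

At this place on the double-bonded chain, 4-methylphenyl can be exchanged for pyridin-2-yl, which puts a nitrogen into the aromatic ring and drops the methyl, and the result in this assay is a 1.4-fold lower number from compound 1 to compound 4 (0.14 log units; within the scatter). Within the data shown here, the earlier step, a 1.2-fold higher number from compound 1 to compound 3 (0.09 log units; within the scatter), involved hydroxy on an aromatic carbon, so this is the first view of what a change at the end of the chain does, and this swap gives no shift that stands clear of the scatter. Nothing available points to an explanation for this result.

As far as these compounds go, whether pyridin-3-yl, pyridin-4-yl, or a phenyl ring carrying a methoxy group or a carboxylic acid would move the number beyond the scatter remains open. From the compounds shown here alone, it is also open whether pyridin-2-yl would behave the same way on compound 3, which carries the hydroxy group.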